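The compounds below may be only part of what the source reports. "The series", "measured", "known", "first", "only" and "open" are said of these compounds alone.

Working notes on the series.

Of the compounds shown here, two of this set have been measured in a functional assay on MCF7 cells (Homo sapiens) for antiproliferative activity; a higher number here means a weaker inhibitor, a lower number a stronger inhibitor. Compound 1 `CSc1nc2c([nH]1)C(=O)C(Br)=C(Br)C2=O` gives 40.3 uM in this assay. Compound 2 `COC1=CC(=O)c2[nH]c(SC)nc2C1=O` gives 36 uM in this assay, and the number for compound 2 sits so close to that of compound 1 that the two fall within the usual scatter of repeated measurements; on the numbers available, compound 2 is not separated from compound 1.

The next step leaves the shared core untouched and alters only the substituent on the five-membered ring: compound 3 `COC1=CC(=O)c2[nH]c(-c3ccccn3)nc2C1=O` carries pyridin-2-yl in place of methylsulfanyl on an aromatic carbon. Within the data shown here, no measured pair shows what such an exchange does, so the direction and size of the step rest on no precedent here. Given that the only two measured compounds agree within the scatter, a moderate step in this assay is expected, with no firm direction, and the estimated step from compound 2 to compound 3 is a 1.2-fold lower number from compound 2 to compound 3 (0.08 log units; within the scatter). For compound 3 the estimate in this assay is 30 uM, expected to lie between 8 uM and 100 uM.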

Compound 3, concentration for 50% inhibition: 26.4 uM
Estimate against measurement, compound 3: 1.1-fold (0.06 log units) above; the range from low to high includes it.
By their numbers in this assay, from the lowest: compounds 3, 2 and 1 (each within the scatter of the next).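

Among these compounds, at the aromatic carbon between two ring nitrogen atoms, compound 2 and compound 3 form the first pair that differs in one place, and in this assay the exchange of methylsulfanyl for pyridin-2-yl reads as a 1.4-fold lower number from compound 2 to compound 3 (0.13 log units; within the scatter). A group with no ring and a group with one six-membered aromatic ring at this carbon are therefore not separated by their numbers, so on this single pair the position accepts the ring without a step that can be told from the scatter. Nothing available bears on why the two numbers agree.

Still open, from the compounds shown here alone, is whether an amine, a carboxylic acid or a longer chain at this carbon, or a phenyl ring in place of pyridin-2-yl, would give a step beyond the scatter. The rest of the shared core also remains unresolved, since compound 1 differs from compound 2 and from compound 3 in more than one place and those steps cannot be read.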